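Chloro for Bromo on Two Related Cores

The source may hold more compounds than are shown below. What is called first, only, known or untested is meant among the compounds shown, and "the series" means these compounds.

Compound 1 `COC(=O)[C@@]1(C)CCC=C2[C@@H]1CC[C@@H](C)[C@]2(C)Cc1c[nH]c2c(Br)cccc12` and compound 2 `COC(=O)[C@@]1(C)CCC=C2[C@@H]1CC[C@@H](C)[C@]2(C)Cc1c[nH]c2c(Cl)cccc12` share one core; compound 3 `COC(=O)[C@@]1(C)CC[C@@H]2C3=C1CC[C@@H](C)[C@]3(C)C[C@@H]1c3cc(Br)ccc3N[C@H]21` and the unmeasured compound 4 `COC(=O)[C@@]1(C)CC[C@@H]2C3=C1CC[C@@H](C)[C@]3(C)C[C@@H]1c3cc(Cl)ccc3N[C@H]21` share another, and the difference between the two cores is not broken down here. In a functional assay on T47D cells (Homo sapiens) for inhibition, read by sulforhodamine B assay, with a stated time of 48 h (on this read-out lower numbers stand for stronger inhibition of growth and higher numbers for weaker inhibition of growth), compound 1 gives 24000 nM and compound 2 gives 24000 nM, so the step of no change at the digits printed from compound 1 to compound 2 (within the scatter), a change of chloro in place of bromo on an aromatic carbon. In this assay compound 3 gives 31000 nM. The change from compound 3 to compound 4 is chloro in place of bromo on an aromatic carbon, the same kind of change but not the same: in compound 1 the place is ortho to a fused ring and meta to a fused ring in a system of two rings, whereas in compound 3 it is meta to a fused ring and para to a fused ring in a system of five rings. Because no change at the digits printed from compound 1 to compound 2 (within the scatter) showed no movement, the step of no change at the digits printed from compound 3 to compound 4 (within the scatter) is expected to be equally small. Compound 4 is therefore estimated at 31000 nM.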

Compound 4, concentration for 50% growth inhibition: 28000 nM
Beside the measured number, compound 4's estimate is 1.1-fold (0.04 log units) above it; the range from low to high includes it.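

In this assay, putting chloro in place of bromo on an aromatic carbon gives a 1.1-fold lower number from compound 3 to compound 4 (0.04 log units; within the scatter). Set beside the earlier step, the swap behaves alike on the two cores: the same change on two cores in this assay, no change at the digits printed (within the scatter) from compound 1 to compound 2 and a 1.1-fold lower number (0.04 log units; within the scatter) from compound 3 to compound 4, 1.1-fold (0.04 log units) apart, within the scatter of two such steps. This shows only that these two halogens can stand in for each other on these two cores, at the two places tested and in this one cell assay; it does not show that any other change would carry across the cores, or why this one leaves the numbers where they are.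

Going by these compounds, it remains open whether a fluoro or a methoxy group at these places would behave the same way. Also open, on these data alone, is what a carboxylic acid in place of the methyl ester would do on either core.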